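The compounds below may be only part of what the source reports. "The series", "measured", "known", "first", "only" and "open" are said of these compounds alone.

Measured compounds:
Compound 1, `CC(C)CN(CC(C)C)c1ccc(/C(=N/O)Nc2ccc(F)c(Br)c2)cc1NC(=O)Nc1ccc(Cl)cc1`: 1490 nM
Compound 2, `Cc1ccc(N/C(=N\O)c2ccc(N(CC(C)C)CC(C)C)c(NC(=O)Nc3cncnc3)c2)cc1`: 2320 nM

For the measured compounds named here, in an assay on isolated protein for inhibition of Indoleamine 2,3-dioxygenase 1 (Homo sapiens) (a lower number here means a stronger inhibitor, a higher number a weaker inhibitor), compound 1 gives 1490 nM, the lowest of the two numbers so far. Compound 2, built on the same core with a different urea partner and a different oxime-bearing aniline, gives 2320 nM. Going by the values given here, the gap between the two lies within the scatter of repeated measurements, so the two values show no order between compound 1 and compound 2, and no step between measured compounds has been worked out for this series.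

The next compound, compound 3, `CC(C)CN(CC(C)C)c1ccc(/C(=N/O)Nc2ccc(F)c(Br)c2)cc1NC(=O)Nc1ccc(C(F)(F)F)cc1`, has not yet been measured in this assay. It is compound 1 altered at one spot: trifluoromethyl in place of chloro on an aromatic carbon. Nothing counted in this exchange adds or removes a hydrogen-bond donor, an acceptor, a ring or a charge; only the identity and size of the group on that aromatic carbon change. Among the compounds with values here, with no measured step covering this position, the expectation rests on compound 1 alone, and a step in this assay of modest size, in either direction or none beyond the scatter, is expected. Compound 3 is expected to give 1500 nM, with a range from 600 nM to 4000 nM. This estimate amounts to an expected step of a 1.0-fold higher number from compound 1 to compound 3 (0.00 log units; within the scatter).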

Compound 3, half-maximal inhibitory concentration: > 3000 nM
Compound 3: only a limit was reported; the forecaster's own chance of this, stated with the estimate: 5%; middle value at least 2.0-fold (0.30 log units) from the limit.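

In this assay, for the compounds shown here, this is the first reading at this position of the shared core: trifluoromethyl in place of chloro on the aromatic carbon para to a large group amounts to an at least 2.0-fold higher number from compound 1 to compound 3 (0.30 log units; that floor lies within the scatter). The value of compound 3 is a limit and not a number, the only such value among the compounds shown: the limit of > 3000 nM in this assay, at which 1 of the 3 values shown sits. The exchange therefore gives no sign that trifluoromethyl improves on chloro at this position, but the floor of the step lies within the scatter, so it does not establish a real loss, and how large the step may be cannot be read.

The compounds shown leave open how a fluoro, a methoxy, an amine or a carboxylic acid on this aromatic carbon would compare with chloro, and whether a number for trifluoromethyl can be had at all in this assay. From the compounds shown here alone, compound 2 differs from compound 1 in more than one place, so it adds nothing to the reading of this position, and whether the same exchange would behave alike on another aniline remains unknown.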